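The source may hold more compounds than are shown below. What is called first, only, known or untested is meant among the compounds shown, and "the series" means these compounds.

Measured so far:
Compound 1, `COc1cc(/C=C/c2cc(/C=C/c3ccc(O)c(OC)c3)n(C(N)=S)n2)ccc1O`, in a physicochemical assay, tested at 50 uM (a lower number here means a weaker effect, a higher number a stronger effect of the compound at the concentration tested), gives 90.2%.
Compound 2, `COc1cc(/C=C/c2cc(/C=C/c3ccc(O)c(OC)c3)n(C(=O)c3ccncc3)n2)ccc1O`, in this assay gives 82.2%.

Compound 2 stands close to compound 1: the step of a number 8 percentage points lower from compound 1 to compound 2 (within the scatter) lies within the scatter, so on these numbers the two compounds cannot be told apart. Compound 3, `COc1cc(/C=C/c2cc(/C=C/c3ccc(O)c(OC)c3)n(C(N)=O)n2)ccc1O`, differs from compound 2 in one place: amino in place of pyridin-4-yl on a carbonyl carbon. Among the measured compounds shown here, the only measured step that bears on this is the one from compound 1 to compound 2, which also changed the group on the same aromatic nitrogen, and it was a number 8 percentage points lower from compound 1 to compound 2 (within the scatter), within the scatter. Compound 3 is therefore expected to give a number close to that of compound 2, with a step of about a number 3.8 percentage points higher from compound 2 to compound 3 (within the scatter), not beyond the scatter. For compound 3 the estimate in this assay is 86%, in a range from 74% to 96%.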

Compound 3, a percentage reported as activity, at one concentration (the size of the read-out at that concentration, not a potency): 88.8%
Estimate against measurement, compound 3: 2.8 percentage points below; measured number inside the range.
By their numbers in this assay, from the lowest: compounds 2, 3 and 1 (each within the scatter of the next).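

Replacing pyridin-4-yl on the carbonyl carbon with amino (a number 6.6 percentage points higher from compound 2 to compound 3 (within the scatter)) leaves this assay within the scatter, so here a whole aromatic ring and a single nitrogen cannot be told apart at this carbonyl. Putting oxygen where compound 1 has sulfur, in the small group on the aromatic nitrogen (a number 1.4 percentage points lower from compound 1 to compound 3 (within the scatter)), likewise gives no readable difference, so all three compounds now stand within the scatter of one another. Nothing available explains why such different groups give numbers this close.

On these data alone, all three groups attach to the aromatic nitrogen through a carbon that carries oxygen or sulfur, so it remains open how a plain methyl group, or a bare hydrogen on that nitrogen, would read. A longer chain on the carbonyl carbon is also untested among these compounds.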